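The compounds below may be only part of what the source reports. "The series", "measured", "known", "first", "only" and "open" are said of these compounds alone.

Compound 1 `COc1ccc(Oc2ccc3c(NCCCNCc4cc(F)ccc4OC)ccnc3c2)cc1` gives 9.28 in a physicochemical assay for acid dissociation. Compound 3 `COc1ccc(Oc2ccc3c(NCCCNCc4cccc(OC)c4O)ccnc3c2)cc1` sits level with it at 9.28, and the step of no change at the digits printed from compound 1 to compound 3 (within the scatter) lies within the scatter. Compound 2 `COc1cccc(CNCCCNc2ccnc3cc(-c4ccc(C(C)(C)C)cc4)ccc23)c1O` gives 9.47, the step of a number 0.19 log units lower from compound 2 to compound 3 (within the scatter) again falling within the scatter, so compound 1 and compound 3 share the lowest of the three numbers without any ordering beyond noise. Compound 4 `COc1ccc(-c2ccc3c(NCCCNCc4cc(F)ccc4OC)ccnc3c2)cc1` is not yet measured; it differs from compound 1 by 4-methoxyphenyl in place of 4-methoxyphenoxy on an aromatic carbon. Going by the values given here, the only step that bears on this change is that from compound 2 to compound 3, an exchange on an aromatic carbon that moved the read-out by a number 0.19 log units lower from compound 2 to compound 3 (within the scatter), within the scatter. A comparable outcome is therefore expected, with a number 0.07 log units higher from compound 1 to compound 4 (within the scatter) for compound 4. Compound 4 is estimated at 9.35, within 9 to 9.7.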

Compound 4, acid dissociation constant: 9.47
The estimate for compound 4 lay 0.12 log units below the measured number, and the stated range covers the measured number.
By their numbers in this assay, from the lowest: compounds 1, 3, 2 and 4 (each within the scatter of the next).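

In this assay the exchange of 4-methoxyphenoxy for 4-methoxyphenyl on this aromatic carbon gives a number 0.19 log units higher from compound 1 to compound 4 (within the scatter) with the rest of the structure held fixed. Going from 9 heavy atoms to 8 and from 2 hydrogen-bond acceptors to 1 at this position thus moves the number by no more than the scatter. No measurement shown accounts for this step. From the compounds shown here alone, what an amine or a carboxylic acid on this aromatic carbon would do remains open. So does whether the same exchange behaves alike with 2-hydroxy-3-methoxyphenyl on the chain.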